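This account rests on a few compounds, and the source may have more. Where it says the series, first, only, none or still open, it means among the compounds named here.

Compound 1 `CCC(c1ccc(Br)cc1)(C(C)O)n1ncc2c(NS(C)(=O)=O)cccc21`: 0.8 h
Compound 2 `CCC(O)C(CC)(c1ccc(C(F)(F)F)cc1)n1ncc2c(NS(C)(=O)=O)cccc21`: 1.2 h

In an ADME assay on microsomes from liver (Homo sapiens) for metabolic stability (a lower number here means that the compound disappears faster, a higher number that the compound lasts longer), compound 2 gives 1.2 h, and compound 1 gives 0.8 h. These two values lie within the usual scatter of each other, so they cannot be ranked. Compound 3 `CCC(c1ccc(C(F)(F)F)cc1)(C(O)C(F)F)n1ncc2c(NS(C)(=O)=O)cccc21` has difluoromethyl in place of ethyl on a saturated chain carbon bound to an oxygen on a saturated carbon and a saturated chain carbon. Among the measured compounds shown here, no measured pair differs in one place only, so no earlier step offers a guide. The estimated change is a 1.3-fold higher number from compound 2 to compound 3 (0.12 log units; within the scatter), a small rise expected to stay within the scatter. For compound 3 the expected half-life is 1.6 h, with an estimated range of 0.7 h to 3.5 h.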

Compound 3, half-life: 1.03 h
Beside the measured number, compound 3's estimate is 1.6-fold (0.19 log units) above it; measured number inside the range.
By their numbers in this assay, from the lowest: compounds 1, 3 and 2 (each within the scatter of the next).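

In this assay, changing 1-hydroxypropyl to 2,2-difluoro-1-hydroxyethyl gives a step (a 1.2-fold lower number from compound 2 to compound 3 (0.07 log units; within the scatter)) that lies within the scatter. Among the compounds shown here, this is the first comparison here that differs in one place only, and it shows that difluoromethyl and ethyl cannot be told apart at this position in this assay. No measurement at hand offers an explanation for this result. Still open, on these data alone, is whether a clearly different group in the same place, such as an amine, a carboxylic acid or a longer chain, would move the half-life beyond the scatter.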